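Swapping thiophen-3-yl for phenyl on an inactive pair

This account rests on a few compounds, and the source may have more. Where it says the series, first, only, none or still open, it means among the compounds named here.

Measured in a functional assay on K562 cells (Homo sapiens), read by MTT assay, with a stated time of 72 h; on this read-out lower numbers stand for stronger inhibition and higher numbers for weaker inhibition:
Compound 1 `CNc1ncnc2c1c(-c1ccoc1)cn2[C@@H]1O[C@H](CO)[C@@H](O)[C@H]1O`: > 20000 nM
Compound 2 `CNc1ncnc2c1c(-c1ccsc1)cn2[C@@H]1O[C@H](CO)[C@@H](O)[C@H]1O`: > 20000 nM

Compound 1 reports only a limit, not a number. Compound 2 also reports only a limit, > 20000 nM. Both compounds therefore stand at the limit of > 20000 nM in this assay, at which 2 of the 2 values shown sit.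

Compound 3 `CNc1ncnc2c1c(-c1ccccc1)cn2[C@@H]1O[C@H](CO)[C@@H](O)[C@H]1O` keeps the shared core and changes one group: phenyl in place of thiophen-3-yl on an aromatic carbon. That is phenyl in place of thiophen-3-yl on an aromatic carbon.

Among the measured compounds shown here, the only measured step that bears on this is another swap of one ring group for another, a step that the two limits leave unreadable from compound 1 to compound 2. Its size cannot be read, so it offers no size or direction to carry over. No step beyond the scatter is expected in this assay, and another limit is the likeliest result.

For compound 3 the estimated value is 25000 nM, with an expected range of 10000 nM to 60000 nM. The expected step is a step that the limit leaves unreadable from compound 2 to compound 3.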

Compound 3, half-maximal inhibitory concentration: > 20000 nM
Compound 3 ended at the assay's limit; the forecaster's own chance of this, stated with the estimate: 85%; the middle value lies beyond the limit too.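

In this assay, among the compounds shown here, compound 3 gives > 20000 nM, which is a limit and not a number, so no step linking it to compound 1 or compound 2 can be read. The compounds shown leave open whether any group at this place gives measurable inhibition, and how compound 1, compound 2 and compound 3 truly compare: the limit of > 20000 nM in this assay, at which 3 of the 3 values shown sit.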